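The source may hold more compounds than are shown below. What is called first, only, known or untested is meant among the compounds shown, and "the series" means these compounds.

In a physicochemical assay for solubility, read by spectrophotometry, in phosphate buffer, with a stated time of 18 h, at pH 7.4 (a lower number here means a less soluble compound, a higher number a more soluble compound), compound 1 (`Cc1cccc(-c2nc3c(c(C)nn3-c3ccccc3)c(-c3ccccc3O)c2C#N)c1`), which carries 3-methylphenyl, gives 42000 nM. Compound 2 (`Cc1nn(-c2ccccc2)c2nc(-c3ccc(C(F)(F)F)cc3)c(C#N)c(-c3ccccc3O)c12`), with 4-(trifluoromethyl)phenyl, gives 3500 nM. Compound 3 (`Cc1nn(-c2ccccc2)c2nc(-c3ccc(I)cc3)c(C#N)c(-c3ccccc3O)c12`), with 4-iodophenyl, gives 1500 nM, the lowest of the three numbers. Compound 4 (`Cc1nn(-c2ccccc2)c2nc(-c3ccc(C#N)cc3)c(C#N)c(-c3ccccc3O)c12`) keeps the rest of compound 3 and has cyano in place of iodo on an aromatic carbon, para to a large group (cyano in place of iodo on an aromatic carbon). Two measured steps are large, a 12-fold lower number from compound 1 to compound 2 (1.08 log units; beyond the scatter) and a 28-fold lower number from compound 1 to compound 3 (1.45 log units; beyond the scatter), but both start from 3-methylphenyl and so make a different change. Among the measured compounds shown here, the closest precedent is the modest step of a 2.3-fold lower number from compound 2 to compound 3 (0.37 log units; beyond the scatter), where only the group on the phenyl ring is exchanged. For the measured compounds named here, no measured compound carries cyano on that ring, so the direction is uncertain. With compound 3 at the bottom of the series at 1500 nM, a modest rise is expected in this assay. The expected step is a 2.7-fold higher number from compound 3 to compound 4 (0.43 log units; beyond the scatter). For compound 4 the estimate is 4000 nM, with an expected range of 1200 nM to 14000 nM.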

Compound 4, solubility: 1700 nM
Compound 4: the middle estimate sits 2.4-fold (0.37 log units) above what was measured, and the stated range covers the measured number.
By their numbers in this assay, from the lowest: compounds 3 and 4 (each within the scatter of the next); then compound 2; then compound 1.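

In this assay the exchange of iodo for cyano on this ring, para to a large group, gives a 1.1-fold higher number from compound 3 to compound 4 (0.05 log units; within the scatter) and so does not separate the two groups, even though cyano brings one more heavy atom and a hydrogen-bond acceptor. Trifluoromethyl at the same place stays modestly apart from both, with a 2.1-fold lower number from compound 2 to compound 4 (0.31 log units; beyond the scatter) alongside a 2.3-fold lower number from compound 2 to compound 3 (0.37 log units; beyond the scatter), while a 25-fold lower number from compound 1 to compound 4 (1.39 log units; beyond the scatter) places the 4-cyanophenyl compound with the 4-iodophenyl and 4-(trifluoromethyl)phenyl compounds, far from the 3-methylphenyl compound. Nothing available offers an explanation for these numbers.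

On these data alone, whether an amine or a carboxylic acid on this ring would stay close to these three compounds remains open. As far as these compounds go, it is also open how much of the large step from 3-methylphenyl belongs to the groups themselves and how much to where they sit on the ring.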